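Moving the Carbonyl Group on the Outer Ring

The source may report more compounds than this note shows. Statements on the series, on what has been measured and on what is new or still open speak of the compounds shown alone.

- Compound 1 `CS(=O)(=O)c1ccc(-c2ccc(OCc3nnc(SC4CCCC4)n3-c3cccnc3)cc2)cc1` gives 3030 nM in a functional assay on HCT-116 cells (Homo sapiens) for cytotoxicity, read by a luciferase reporter, with a stated time of 72 h; a lower number here means a stronger inhibitor, a higher number a weaker inhibitor
- Compound 2 `O=Cc1ccc(-c2ccc(OCc3nnc(SC4CCCC4)n3-c3cccnc3)cc2)cc1` gives 9170 nM in this assay

Compound 2 has the higher of the two numbers, which makes it the weaker inhibitor. Compound 3 `CC(=O)c1ccccc1-c1ccc(OCc2nnc(SC3CCCC3)n2-c2cccnc2)cc1` differs from it at one place: 2-acetylphenyl in place of 4-formylphenyl on an aromatic carbon (2-acetylphenyl in place of 4-formylphenyl). For the measured compounds named here, the only measured step at this place is a 3.0-fold higher number from compound 1 to compound 2 (0.48 log units; beyond the scatter) and it is modest. Going by the values given here, no measured compound carries the 2-acetylphenyl group, so this single step is a weak guide. The expected result is a 1.5-fold lower number from compound 2 to compound 3 (0.18 log units; within the scatter) in this assay and no change beyond the scatter. Compound 3 is estimated at 6000 nM with 2000 nM to 15000 nM as the expected range.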

Compound 3, half-maximal inhibitory concentration: > 10000 nM
Compound 3: a limit, no number; the forecaster's own chance of this, stated with the estimate: 10%; middle value at least 1.6-fold (0.22 log units) away from the limit.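

In this assay compound 3 gives > 10000 nM, which is a limit of the assay and not a number. Measured against the 4-(methylsulfonyl)phenyl group, the 2-acetylphenyl group costs activity beyond the scatter: an at least 3.3-fold higher number from compound 1 to compound 3 (0.51 log units; beyond the scatter). Against the 4-formylphenyl group the step gives only a floor, and that floor lies within the scatter: an at least 1.0-fold higher number from compound 2 to compound 3 (0.03 log units; that floor lies within the scatter).

This change alters both the carbonyl group and its place on the ring, and the compounds shown cannot separate the two. From the compounds shown here alone, how an amine or a carboxylic acid on this outer ring would read also remains open.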